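Swapping methoxy for chloro: expectations for compound 4

A few compounds are considered here, and "the series" means these few. Any claim that something is new, unique, unknown or untested is made for them only; others in the source may bear on it.

Compound 1 `N=C(S)CCN1N=C(c2cccs2)CCC1=O`: 77.3 mg/kg
Compound 2 `C/N=C(\S)CCn1ncccc1=O`: > 100 mg/kg
Compound 3 `COc1ccc(-c2ccc(=O)n(CCC(=N)S)n2)cc1`: > 100 mg/kg

All three numbers come from a functional assay on the whole organism (stomach) with Rattus norvegicus as the target (on this read-out higher numbers stand for an effect only at larger amounts of compound and lower numbers for an effect already at smaller amounts), measured in the rat. Compound 1 gives a real number, 77.3 mg/kg. Compound 2 reaches only a limit of the assay, > 100 mg/kg, not a number. Compound 3 likewise ends at a limit, > 100 mg/kg, so its true dose is not known; it sits at the limit of > 100 mg/kg in this assay, at which 2 of the 3 values shown sit, together with one other of the three values shown. Within the data shown here, no two measured compounds differ in a single place, so no measured step is available to lean on.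

Compound 4 `N=C(S)CCn1nc(-c2ccc(Cl)cc2)ccc1=O` differs from compound 3 by chloro in place of methoxy on an aromatic carbon. Among the measured compounds shown here, with no measured step of this kind, the change is expected to bring no step beyond the scatter, and compound 4 is expected to stay near the limit. Compound 4 is expected to give 130 mg/kg, with a range from 60 mg/kg to 300 mg/kg. The step this estimate means is expected to be a step that the limit leaves unreadable from compound 3 to compound 4.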

Compound 4, dose for half-maximal effect: > 100 mg/kg
Compound 4: no number, only a limit; the forecaster's own chance of this, stated with the estimate: 70%; the middle value is on the limit's open side.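

Compound 3 and compound 4 both end at a limit in this assay rather than at a number, so swapping methoxy for chloro gives no readable step: the limit of > 100 mg/kg in this assay, at which 3 of the 4 values shown sit. From the compounds shown here alone, whether this swap changes the dose needed at all, and in which direction, stays open.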